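A few compounds are considered here, and "the series" means these few. Any claim that something is new, unique, unknown or untested is made for them only; others in the source may bear on it.

Working notes on the series.

Compound 1 `Cc1ccc(C2=NN(c3nc(-c4ccccc4)c(C#N)c(=O)n3C)C(c3ccc(F)cc3)C2)cc1` is the reference. In a functional assay on MDA-MB-231 cells (Homo sapiens) for antiproliferative activity, with a stated time of 72 h (a higher number here means a weaker inhibitor, a lower number a stronger inhibitor), compound 1 gives 5100 nM. Compound 3 `Cc1ccc(C2=NN(c3nc(-c4ccc(Cl)cc4)c(C#N)c(=O)n3C)C(c3ccc(F)cc3)C2)cc1` carries one change relative to compound 1, namely (chloro in place of hydrogen on an aromatic carbon), and in this assay compound 3 gives 19300 nM. That single change produced a 3.8-fold higher number from compound 1 to compound 3 (0.58 log units; beyond the scatter).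

Compound 2 `Cn1c(N2N=C(c3ccccc3)CC2c2ccccc2)nc(-c2ccc(Cl)cc2)c(C#N)c1=O` belongs to a second core; how its core differs from that of compound 1 is not broken down here. In this assay, for the measured compounds named here, compound 2 gives 29100 nM, which is the highest of the three numbers so far, beyond the scatter relative to compound 1 but within the scatter relative to compound 3, so no ordering of compound 2 against compound 3 is claimed.

Compound 4 `Cn1c(N2N=C(c3ccc(Cl)cc3)CC2c2ccccc2)nc(-c2ccc(Cl)cc2)c(C#N)c1=O` is the counterpart of compound 2 with chloro in place of hydrogen on an aromatic carbon. The two place descriptions read identically, so the change is taken as the same one that separates compound 1 from compound 3, here applied to a different core. The expectation for compound 4 rests on compound 1 and compound 3, where the step was a 3.8-fold higher number from compound 1 to compound 3 (0.58 log units; beyond the scatter); the different core of compound 2 means the step could be smaller or larger, so the range is kept wide. The step expected from compound 2 to compound 4 in this assay is a 2.4-fold higher number from compound 2 to compound 4 (0.38 log units; beyond the scatter). Compound 4 is therefore estimated at 70000 nM in this assay, with a plausible span from 25000 nM to 200000 nM.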

Compound 4, half-maximal inhibitory concentration: 12400 nM
The estimate for compound 4 lay 5.6-fold (0.75 log units) above the measured number; the measured number lies below the stated range.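

In this assay, chloro in place of hydrogen on an aromatic carbon gives a 2.3-fold lower number from compound 2 to compound 4 (0.37 log units; beyond the scatter), so on this core the change goes with a lower number, not a higher one. Set beside the earlier step, the change does not carry from one core to another in this series with its direction or its size intact: the same change on two cores in this assay, a 3.8-fold higher number (0.58 log units; beyond the scatter) from compound 1 to compound 3 and a 2.3-fold lower number (0.37 log units; beyond the scatter) from compound 2 to compound 4, 8.9-fold (0.95 log units) apart, beyond the scatter of two such steps. This rests on only two pairs, and the structures show that a different phenyl takes the chloro in each pair, so the gap cannot be assigned to the core alone and no mechanism for it is shown.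

As far as these compounds go, it remains open whether the two cores would still part ways if the chloro entered on the matching phenyl in both, and whether the opposite steps would hold in a wider set of matched pairs. Also open, from the compounds shown here alone, is whether a bromo, a methoxy, an amine or a carboxylic acid in place of the chloro would follow the step from compound 1 to compound 3, the step from compound 2 to compound 4, or neither.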